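Cyclohexyl for propyl on a shared amidine-bearing core

A few compounds are considered here, and "the series" means these few. Any claim that something is new, unique, unknown or untested is made for them only; others in the source may bear on it.

Three compounds of one series were measured in an assay for inhibition of acid-sensing ion channel 3 (Homo sapiens), read by patch clamp, tested at 20 uM; on this read-out higher numbers stand for more inhibition at the one concentration tested (going by the name of the read-out) and lower numbers for less inhibition. Compound 1 `NC(N)=NC(=O)c1nc(Cl)c(NCc2ccccc2Cl)nc1N` gives 90%. Compound 2 `CCCNc1nc(N)c(C(=O)N=C(N)N)nc1Cl` gives 91%, the highest of the three numbers, although every gap to it lies within the scatter: a number 1 percentage points higher from compound 1 to compound 2 (within the scatter). Compound 3 `NC(N)=NC(=O)c1nc(Cl)c(NCc2cccc(F)c2)nc1N` gives 90%, and a number 1 percentage points lower from compound 2 to compound 3 (within the scatter); between the two benzyl-type compounds, no change at the digits printed from compound 1 to compound 3 (within the scatter).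

Compound 4 `NC(N)=NC(=O)c1nc(Cl)c(NC2CCCCC2)nc1N` has not been measured. It differs from compound 2 as follows: cyclohexyl in place of propyl on a nitrogen on an aromatic ring. Among the compounds with values here, the steps that bear on this exchange are the two that swap the group on the saturated chain carbon bound to the ring nitrogen, from compound 1 to compound 2 and from compound 2 to compound 3, and both stayed within the scatter. On that basis no step beyond the scatter is expected, and the change from compound 2 to compound 4 is estimated as a number 2 percentage points lower from compound 2 to compound 4 (within the scatter). Compound 4 is therefore expected to give about 89% in this assay, within a range from 76% to 97%.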

Compound 4, a percentage reported as inhibition, at one concentration (the size of the read-out at that concentration, not a potency): 92%
The estimate for compound 4 lay 3 percentage points below the measured number, within the range that was stated.
By their numbers in this assay, from the lowest: compounds 1, 3, 2 and 4 (each within the scatter of the next).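

In this assay, cyclohexyl in place of propyl on a nitrogen on an aromatic ring gives a number 1 percentage points higher from compound 2 to compound 4 (within the scatter). So this position also accepts a six-membered non-aromatic ring of carbon only, with 6 heavy atoms against the 3 of propyl, without a step beyond the scatter, whereas the earlier compounds tested only groups joined through a saturated chain carbon. No measurement is at hand that would explain this result.

The compounds shown leave open whether an amine or a carboxylic acid on the cyclohexyl ring, or a longer chain on this nitrogen, would stay within the scatter of compound 2. Since the read-out is taken at one concentration, they also leave open whether compound 2 and compound 4 differ in potency.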